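Trifluoromethyl to nitro: solubility expected for compound 4

The source may hold more compounds than are shown below. What is called first, only, known or untested is meant among the compounds shown, and "the series" means these compounds.

In a physicochemical assay for solubility, read by HPLC, at pH 7.4 (on this read-out lower numbers stand for lower solubility and higher numbers for higher solubility), compound 2 (`CCOCCCCc1cc(=O)c2ccccc2[nH]1`) gives > 200000 nM, which is a limit of the assay. Compound 3 (`CCOCCCCc1cc(=O)c2cc(C(F)(F)F)ccc2[nH]1`) gives > 200000 nM, also a limit of the assay, so it sits at the limit of > 200000 nM in this assay, at which 2 of the 3 values shown sit, and no exact number is available for it. Within the data shown here, the only measured step on the shared core is a step that the two limits leave unreadable from compound 2 to compound 3, and it provides no size to carry forward.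

Compound 4 (`CCOCCCCc1cc(=O)c2cc([N+](=O)[O-])ccc2[nH]1`) differs from compound 3 by this change: nitro in place of trifluoromethyl on an aromatic carbon. Compound 1 (`CCCCCCCc1cc(=O)c2cc([N+](=O)[O-])ccc2[nH]1`) also carries nitro, but on a heptyl chain rather than the ethoxybutyl chain. Compound 1 gives < 5000 nM, a limit of the assay. Among the measured compounds shown here, no measured step isolates nitro, so only a modest fall in this assay is expected, and it may not be readable. That expectation starts from compound 3 at > 200000 nM, a limit. The estimated size is an at least 1.6-fold lower number from compound 3 to compound 4 (0.22 log units; that floor lies within the scatter). Compound 4 is estimated at 120000 nM, with an expected range of 50000 nM to 300000 nM.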

Compound 4, solubility: 50000 nM
Estimate against measurement, compound 4: 2.4-fold (0.38 log units) above, and the stated range covers the measured number.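

Among these compounds, at this aromatic carbon, nitro gives the first exact number on the ethoxybutyl chain: in this assay the change from trifluoromethyl gives an at least 4.0-fold lower number from compound 3 to compound 4 (0.60 log units; beyond the scatter), and the change from hydrogen gives an at least 4.0-fold lower number from compound 2 to compound 4 (0.60 log units; beyond the scatter). With nitro held in place, ethoxy in place of propyl on the chain gives an at least 10-fold higher number from compound 1 to compound 4 (1.00 log units; beyond the scatter), so the chain change also has a readable lower bound at this position. Each of these three steps starts from a limit of the assay, so each gives a minimum size and not an exact one.

On these data alone, the true sizes of the nitro and chain steps stay open, as do any order between trifluoromethyl and hydrogen at this position. Also open, as far as these compounds go, is where an amine or a carboxylic acid on this aromatic carbon would fall on this read-out, with the ethoxybutyl chain kept.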